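The source may hold more compounds than are shown below. What is called first, only, known or untested is meant among the compounds shown, and "the series" means these compounds.

Measured in an ADME assay on C2C12 cells (Mus musculus) for cytotoxicity; on this read-out lower numbers stand for higher toxicity in this test and higher numbers for lower toxicity in this test:
- Compound 1 `c1ccc(CNc2nc(Nc3ccccc3)nc3ccccc23)cc1`: > 10000 nM, a limit
- Compound 2 `Oc1cccc(Nc2nc(NCc3ccccc3)c3ccccc3n2)c1`: 10000 nM
- Compound 3 `c1ccc(CNc2nc(Nc3ccccn3)nc3ccccc23)cc1`: > 10000 nM, a limit

Compound 3 stands only at a limit, > 10000 nM. Compound 2, at 10000 nM, is the only one of the three with a number. The next compound, compound 4 `c1ccc(CNc2nc(Nc3nccs3)nc3ccccc23)cc1`, carries 1,3-thiazol-2-yl in place of pyridin-2-yl on a nitrogen on an aromatic ring.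

Among the measured compounds shown here, no measured step makes this exact change. The closest are the other replacements at that nitrogen, a step that the two limits leave unreadable from compound 1 to compound 3 and a number no lower from compound 2 to compound 3 (the limit leaves the size open), and the hydroxy change, a number no higher from compound 1 to compound 2 (the limit leaves the size open). None of the three has a readable size, so they fix no magnitude and only show that these changes left the values at or near one level. The clearest feature of the data is the limit of > 10000 nM in this assay, at which 2 of the 3 values shown sit.

On that basis, no step beyond the usual scatter is expected in this assay, and no direction can be favoured. The expected step is a step that the limit leaves unreadable from compound 3 to compound 4. A result reported only as a limit is the likeliest outcome. For compound 4 the estimated value is 12000 nM, with an expected range from 4000 nM to 30000 nM.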

Compound 4, half-maximal cytotoxic concentration: > 10000 nM
Compound 4 was reported as a limit; the forecaster's own chance of this, stated with the estimate: 70%; the middle value is on the limit's open side.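

In this assay compound 4 gives > 10000 nM, which is a limit of the assay and not a number. This shows that the range of groups on a nitrogen on an aromatic ring, so far made up of six-membered aromatic rings, can extend to a five-membered aromatic ring with 2 hetero atoms, 1,3-thiazol-2-yl, and still give a result reported only as a limit. Compared with the one compound that has a number, the result reads as a number no lower from compound 2 to compound 4 (the limit leaves the size open), and the steps from compound 1 and compound 3 cannot be read, so this change has no measurable size in any comparison, and the series gathers further at one level: the limit of > 10000 nM in this assay, at which 3 of the 4 values shown sit.

The compounds shown leave open how far past that limit any of the limit-bound compounds lies, so the groups at this nitrogen cannot be ranked against one another. They also leave open whether an amine or a carboxylic acid on the group at this nitrogen would give a readable number in this assay.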